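Replacing an Amide Tail with a Fluorophenylethyl Group

The source may hold more compounds than are shown below. What is called first, only, known or untested is meant among the compounds shown, and "the series" means these compounds.

Compound 3 `Cc1cc(C)cc(S(=O)(=O)c2c(C(=O)NCC(=O)NCc3ccco3)[nH]c3ccc(Cl)cc23)c1` is one of three close relatives that share the same core and differ only in the group on the amide nitrogen. In an ADME assay on MT4 cells (Homo sapiens) for cytotoxicity, read by MTT assay (a lower number here means that less compound is tolerated, a higher number that more compound is tolerated), compound 3 reaches only a limit of the measurement, > 50000 nM, so its true number is not known. Compound 1 `Cc1cc(C)cc(S(=O)(=O)c2c(C(=O)NCc3cccc(F)c3F)[nH]c3ccc(Cl)cc23)c1` likewise gives only a limit in this assay, > 51100 nM. Compound 2 `Cc1cc(C)cc(S(=O)(=O)c2c(C(=O)NC(C)C(=O)NCc3ccco3)[nH]c3ccc(Cl)cc23)c1` gives a real number in this assay, 24200 nM. The step of an at least 2.0-fold higher number from compound 2 to compound 3 (0.31 log units; beyond the scatter) is open-ended because of the limit of > 50000 nM in this assay, at which 1 of the 3 values shown sits. From compound 1 to compound 2 the step is an at least 2.1-fold lower number from compound 1 to compound 2 (0.32 log units; beyond the scatter), whereas a step that the two limits leave unreadable from compound 1 to compound 3 cannot be read because of the limit of > 50000 nM in this assay, at which 1 of the 3 values shown sits, together with the limit of > 51100 nM in this assay, at which 1 of the 3 values shown sits.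

Compound 4 `Cc1cc(C)cc(S(=O)(=O)c2c(C(=O)NC(C)c3ccccc3F)[nH]c3ccc(Cl)cc23)c1` is the unmeasured relative. Its change from compound 3 is 1-(2-fluorophenyl)ethyl in place of (((furan-2-yl)methyl)carbamoyl)methyl on an amide-type nitrogen. The entering group resembles the 2,3-difluorobenzyl of compound 1 more than the two-amide chains of compound 2 and compound 3, and compound 1 sits at a limit in this assay, > 51100 nM. Compound 4 is therefore expected to sit at or near the limit as well, with a number no higher from compound 3 to compound 4 (the limit leaves the size open) expected to stay within the scatter. The estimate for compound 4 is 50000 nM, between 22000 nM and 110000 nM.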

Compound 4, half-maximal cytotoxic concentration: > 51500 nM
Compound 4 ended at the assay's limit; the forecaster's own chance of this, stated with the estimate: 60%; at least 1.0-fold (0.01 log units) between middle value and limit.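

In this assay, with the methyl kept on the saturated chain carbon bound to the amide-type nitrogen, 2-fluorophenyl in place of ((furan-2-yl)methyl)carbamoyl gives an at least 2.1-fold higher number from compound 2 to compound 4 (0.32 log units; beyond the scatter), so the methyl alone does not go with the lower number of compound 2. Of the four compounds, only compound 2 carries both the methyl and the ((furan-2-yl)methyl)carbamoyl tail, and only compound 2 gives a real number, while compound 3 has the tail without the methyl and compound 4 has the methyl without the tail. The steps from compound 3 to compound 4 and from compound 1 to compound 4 cannot be read, since each joins two limits: the limit of > 51500 nM in this assay, at which 1 of the 4 values shown sits.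

Going by these compounds, how far the true numbers of compound 1, compound 3 and compound 4 lie past their limits stays unknown. Also open, on these data alone, is whether the lower number seen with compound 2 depends on that exact pairing of groups, or would return with an amine or a carboxylic acid on the same saturated chain carbon, or with a longer chain in place of the methyl.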